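Shortening the ester chain of a malonamide ACAT inhibitor

The source may hold more compounds than are shown below. What is called first, only, known or untested is meant among the compounds shown, and "the series" means these compounds.

Measured compounds:
Compound 1, `CC(C)c1cccc(C(C)C)c1NC(=O)CC(=O)O`, gives > 5000 nM in an assay on microsomes from intestine for inhibition of acyl-CoA:cholesterol acyltransferase (Oryctolagus cuniculus); a higher number here means a weaker inhibitor, a lower number a stronger inhibitor.
Compound 2, `CCCCC(C)(C)OC(=O)CC(=O)Nc1c(C(C)C)cccc1C(C)C`, gives 15 nM.
Compound 3, `CCCCCCCCCCCCOC(=O)CC(=O)Nc1c(C(C)C)cccc1C(C)C`, gives 11 nM.

The value of compound 1 is a limit of the assay and not a number (the limit of > 5000 nM in this assay, at which 1 of the 3 values shown sits). Among the two numbers shown, compound 3 has the lowest, but compound 2 lies within the usual scatter of it, so no order between the two can be claimed.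

Compound 4, `CCCCCCCCOC(=O)CC(=O)Nc1c(C(C)C)cccc1C(C)C`, differs from compound 3 by hydrogen in place of butyl on a saturated chain carbon, eight bonds along the chain from an oxygen next to a carbonyl group, so that an octyl chain remains on the ester oxygen. Among the measured compounds shown here, the only measured step with one change is an at least 330-fold lower number from compound 1 to compound 2 (2.52 log units; beyond the scatter), which shows that the presence of a chain on that oxygen matters greatly. Compound 2 and compound 3 carry very different chains yet give values within the scatter of each other, so the length of the chain, once present, appears to matter little here. The step from compound 3 to compound 4 is therefore expected to be a 1.2-fold higher number from compound 3 to compound 4 (0.07 log units; within the scatter), within the scatter. Compound 4 is estimated to give 13 nM, between 5 nM and 35 nM.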

Compound 4, half-maximal inhibitory concentration: 260 nM
Compound 4: the middle estimate sits 20-fold (1.30 log units) below what was measured; the measured number lies above the stated range.
By their numbers in this assay, from the lowest: compounds 3 and 2 (each within the scatter of the next); then compound 4. At a limit, above all of these: compound 1.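

In this assay, the length of the chain on the ester oxygen does matter, contrary to what compounds 2 and 3 suggested: shortening the chain to octyl gives a 24-fold higher number from compound 3 to compound 4 (1.37 log units; beyond the scatter). The branched 1,1-dimethylpentyl group also cannot be swapped for octyl without a large loss, as a 17-fold higher number from compound 2 to compound 4 (1.24 log units; beyond the scatter) shows, so chains of different shape are not interchangeable here. An octyl chain still counts for much compared with no chain, with an at least 19-fold lower number from compound 1 to compound 4 (1.28 log units; beyond the scatter), that starting value being a limit of the assay and not a number: the limit of > 5000 nM in this assay, at which 1 of the 4 values shown sits.

Among the compounds shown here, how a decyl chain, or a chain longer than the one in compound 3, would read remains open. Also open, as far as these compounds go, is what an amine or a carboxylic acid on the chain would do.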